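This account rests on a few compounds, and the source may have more. Where it says the series, first, only, none or still open, it means among the compounds named here.

In a functional assay on WM1361 cells (Homo sapiens) for inhibition, read by MTT assay, with a stated time of 24 h (a lower number here means a stronger inhibitor, a higher number a weaker inhibitor), compound 3 `O=c1oc2ccccc2c(N2CCN(c3ccc(F)cc3)CC2)c1CO` has no exact number, only a limit of the assay, > 50000 nM. This places compound 3 at the limit of > 50000 nM in this assay, at which 1 of the 3 values shown sits. Two relatives sharing its core do have numbers: compound 1 `COc1cccc(N2CCN(c3c(CO)c(=O)oc4ccccc34)CC2)c1` gives 38100 nM, and compound 2 `O=c1oc2ccccc2c(N2CCN(C(c3ccc(F)cc3)c3ccc(F)cc3)CC2)c1CO` gives 29400 nM.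

The next compound, compound 4 `O=c1oc2ccccc2c(N2CCN(c3cccc(Cl)c3)CC2)c1CO`, carries 3-chlorophenyl in place of 4-fluorophenyl on an amine nitrogen in a ring. Among the compounds with values here, one measured step bears on this change, and it also swaps the group on that nitrogen: 4-fluorophenyl in place of 3-methoxyphenyl gives an at least 1.3-fold higher number from compound 1 to compound 3 (0.11 log units; that floor lies within the scatter). That step offers only a floor, not a measured size, and it shows no change beyond the scatter. Within the data shown here, with this as the only guide, no step beyond the scatter is expected in this assay. The expected change is an at least 1.2-fold lower number from compound 3 to compound 4 (0.09 log units; that floor lies within the scatter), a small estimated step in either direction. Compound 4 is expected to give about 40000 nM, with an estimated range of 18000 nM to 70000 nM.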

Compound 4, half-maximal inhibitory concentration: > 50000 nM
Compound 4: a limit, no number; the forecaster's own chance of this, stated with the estimate: 35%; at least 1.2-fold (0.09 log units) between middle value and limit.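

In this assay, compound 4 gives a limit and not a number, as compound 3 does: the limit of > 50000 nM in this assay, at which 2 of the 4 values shown sit. With limits on both sides, the step between these two compounds cannot be read, so 3-chlorophenyl and 4-fluorophenyl cannot be ranked on this amine nitrogen. Chloro in place of methoxy on an aromatic carbon gives an at least 1.3-fold higher number from compound 1 to compound 4 (0.11 log units; that floor lies within the scatter), so this pair shows no change that stands clear of the usual variation between repeated measurements.

The compounds shown leave open whether a carboxylic acid or a nitrile on the phenyl ring would bring a readable number in this position. They also leave open how the shared core would read with a longer chain on this nitrogen in place of a phenyl ring.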